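A few compounds are considered here, and "the series" means these few. Any claim that something is new, unique, unknown or untested is made for them only; others in the source may bear on it.

Working notes on the series. Compound 1, `COc1cc(Oc2cccc(Nc3ccccc3)c2)cc(OC)c1CNCc1ccc(Br)cc1`, gives 5410 nM in a functional assay on HCT-15 cells (Homo sapiens) for inhibition, read by MTT assay, with a stated time of 72 h; on this read-out lower numbers stand for stronger inhibition and higher numbers for weaker inhibition. Compound 2, `COc1cc(Oc2cccc(Nc3ccccc3)c2)cc(OC)c1CNCc1ccc(Cl)cc1`, gives 4850 nM in this assay, and compound 3, `COc1ccc(CNCc2c(OC)cc(Oc3cccc(Nc4ccccc4)c3)cc2OC)cc1`, gives 2650 nM in this assay. Compound 3 holds the lowest of the three numbers; its gap to compound 2 stays within the scatter, whereas a 2.0-fold lower number from compound 1 to compound 3 (0.31 log units; beyond the scatter) lies just beyond it. The remaining steps are small: a 1.1-fold lower number from compound 1 to compound 2 (0.05 log units; within the scatter) and a 1.8-fold lower number from compound 2 to compound 3 (0.26 log units; within the scatter).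

Compound 4, `COc1cc(Oc2cccc(Nc3ccccc3)c2)cc(OC)c1CCO`, is not yet measured. It differs from compound 3 as follows: hydroxymethyl in place of (4-methoxybenzyl)amino on a saturated chain carbon bound to an aromatic carbon. Among the compounds with values here, none of the measured steps bears directly on this change. All three exchange only the substituent on the ring of the (4-methoxybenzyl)amino group, and all three move the number over a narrow band; here the whole (4-methoxybenzyl)amino group leaves and a hydroxymethyl enters, a far larger departure from the shared core than anything measured so far. Within the data shown here, the three measured values give no precedent for such a truncation, so the direction can only be guessed. The step of a 5.7-fold higher number from compound 3 to compound 4 (0.75 log units; beyond the scatter) is expected to run toward a higher number, with wide uncertainty. Compound 4 is estimated at 15000 nM, with a range from 4000 nM to 60000 nM.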

Compound 4, half-maximal inhibitory concentration: 12100 nM
Beside the measured number, compound 4's estimate is 1.2-fold (0.09 log units) above it, within the range that was stated.
By their numbers in this assay, from the lowest: compounds 3, 2 and 1 (each within the scatter of the next, the first and the last beyond it); then compound 4.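

Replacing the entire (4-methoxybenzyl)amino group with hydroxymethyl, on a saturated chain carbon bound to an aromatic carbon, separates compound 4 from all three earlier compounds in this assay: a 4.6-fold higher number from compound 3 to compound 4 (0.66 log units; beyond the scatter), a 2.5-fold higher number from compound 2 to compound 4 (0.40 log units; beyond the scatter) and a 2.2-fold higher number from compound 1 to compound 4 (0.35 log units; beyond the scatter). The earlier compounds shown here showed only exchanges on the ring of the benzylamino group, whereas this result shows that all three compounds carrying that group give lower numbers than the 2-hydroxyethyl compound, and that a number is still obtained in this assay once the group and its aromatic ring have gone. No measurement at hand bears on the reason for this rise.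

The change removes the nitrogen, the aromatic ring and most of the heavy atoms in one step, so the compounds shown do not assign the rise to any one of these parts. A primary amine, a methylamine or a benzyl ether at the same place would keep some of these parts and lose others, and a carboxylic acid would replace the hydroxymethyl end with a different group.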